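The source may hold more compounds than are shown below. What is called first, only, known or untested is meant among the compounds shown, and "the series" means these compounds.

Measured so far in a functional assay on T98 cells (Homo sapiens) for antiproliferative activity, with a stated time of 5 days; on this read-out higher numbers stand for an effect only at larger amounts of compound and lower numbers for an effect already at smaller amounts:
Compound 1 `Nc1nc2cc(-c3nn(CC4OCCO4)c4ncnc(N)c34)ccc2o1`: 100 nM
Compound 2 `Nc1nc2cc(-c3nn(CC4CCCO4)c4ncnc(N)c34)ccc2o1`: 100 nM
Compound 3 `Nc1nc2cc(-c3nn(CC4CCCC4)c4ncnc(N)c34)ccc2o1`: 10 nM

Compound 2 stands level with compound 1, and together they hold the highest of the three numbers. Its largest gap is a 10-fold lower number from compound 2 to compound 3 (1.00 log units; beyond the scatter).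

The next compound, compound 4 `Nc1nc2cc(-c3nn(C[C@@H]4CCCO4)c4ncnc(N)c34)ccc2o1`, departs from compound 2 in one respect only: the two compounds have the same atoms and bonds; at least one stereo element is drawn with a configuration in one of them and without one in the other: 1 of 1 stereo elements differ; a stereocentre at a saturated ring carbon is drawn without a configuration in compound 2 and S in compound 4. Among the compounds with values here, no measured step changes a stereocentre, so none speaks to this change directly. The nearest evidence concerns the group on the saturated chain carbon bound to an aromatic nitrogen. One such replacement gave no change at the digits printed from compound 1 to compound 2 (within the scatter), and another gave a 10-fold lower number from compound 1 to compound 3 (1.00 log units; beyond the scatter). Both steps exchange the group itself, whereas compound 4 keeps the group of compound 2, so neither size carries over. The data do not show how a drawn S configuration compares with the undefined one, and a move in either direction remains possible. In this assay, no step beyond the scatter is therefore expected, and the estimate is a 1.3-fold lower number from compound 2 to compound 4 (0.10 log units; within the scatter). Compound 4 is expected at 80 nM, with an estimated range of 30 nM to 300 nM.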

Compound 4, half-maximal effective concentration: 100 nM
Beside the measured number, compound 4's estimate is 1.3-fold (0.10 log units) below it, and the stated range covers the measured number.
By their numbers in this assay, from the lowest: compound 3; then compounds 1, 2 and 4 (each within the scatter of the next).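

In this assay, within the data shown here, drawing the oxolan-2-yl group with a defined S configuration gave no change at the digits printed from compound 2 to compound 4 (within the scatter), the first measured step at this stereocentre, and the pair is separated by one feature only: the fact that one of compounds 2 and 4 is drawn with a defined configuration and the other without, at the place where they differ. Set against the 1,3-dioxolan-2-yl group, the S form gave no change at the digits printed from compound 1 to compound 4 (within the scatter), so the level reading shared by the two oxygen-containing rings also holds when the stereocentre is drawn as S. Exchanging cyclopentyl for the S-configured oxolan-2-yl group gave a 10-fold higher number from compound 3 to compound 4 (1.00 log units; beyond the scatter), which matches in size the gap already seen in a 10-fold lower number from compound 2 to compound 3 (1.00 log units; beyond the scatter), so the advantage of cyclopentyl in this assay does not depend on how the stereocentre of the oxolan-2-yl group is drawn.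

The compounds shown leave open how the R configuration of the oxolan-2-yl group would read in this assay, and compound 2, drawn without a configuration, does not settle this. They also leave open whether the gap belongs to ring oxygen as such, which an oxan-2-yl group or a pyrrolidin-2-yl amine on the saturated chain carbon bound to an aromatic nitrogen could test.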